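This account rests on a few compounds, and the source may have more. Where it says the series, first, only, none or still open, it means among the compounds named here.

Measured compounds in a functional assay on HeLa cells (Homo sapiens) for cytotoxicity, read by WST assay, with a stated time of 48 h; a lower number here means a stronger inhibitor, a higher number a weaker inhibitor:

- compound 1 `Cc1ccc(/C=C/C[C@H]2C[C@@H]([C@@H](O)c3ccccc3)CO[C@@H]2c2ccccc2)cc1C`, compound 1 gives 10000 nM
- compound 2 `O[C@@H](c1ccccc1)[C@H]1CO[C@H](c2ccccc2)[C@@H](C/C=C/c2ccncc2)C1`, for compound 2 only a limit of the assay is reached, > 100000 nM
- compound 3 `COc1ccccc1/C=C/C[C@H]1C[C@@H]([C@@H](O)c2ccccc2)CO[C@@H]1c1ccccc1`, compound 3 gives 14700 nM

Compound 3 carries the highest of the two numbers; its nearest neighbour is compound 1, a 1.5-fold higher number from compound 1 to compound 3 (0.17 log units; within the scatter), so the two are not separable. Compound 2 is recorded only as a limit (the limit of > 100000 nM in this assay, at which 1 of the 3 values shown sits).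

Compound 4 `CCCCCC/C=C/C[C@H]1C[C@@H]([C@@H](O)c2ccccc2)CO[C@@H]1c1ccccc1` is not yet measured. It differs from compound 3 in one place: hexyl in place of 2-methoxyphenyl on a double-bonded chain carbon bound to a double-bonded chain carbon.

The measured steps all sit at the same place on the chain, but every one of them exchanges one aromatic ring for another. The largest is an at least 10-fold higher number from compound 1 to compound 2 (1.00 log units; beyond the scatter), its reverse counterpart an at least 6.8-fold lower number from compound 2 to compound 3 (0.83 log units; beyond the scatter), and the smallest a 1.5-fold higher number from compound 1 to compound 3 (0.17 log units; within the scatter). Going by the values given here, no measured step replaces an aromatic ring with a chain, so none bears directly on the move to hexyl. The two carbocyclic rings give numbers within the scatter of each other, which suggests that this position tolerates change, while the pyridin-4-yl case shows it can also lose activity sharply.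

On this basis compound 4 is expected to stay close to compound 3, with a step of a 1.4-fold higher number from compound 3 to compound 4 (0.13 log units; within the scatter) that is estimated as small. The estimate for compound 4 is 20000 nM, within 6000 nM to 80000 nM.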

Compound 4, half-maximal inhibitory concentration: 7400 nM
For compound 4 the middle estimate is 2.7-fold (0.43 log units) above the measured one, within the range that was stated.
By their numbers in this assay, from the lowest: compounds 4, 1 and 3 (each within the scatter of the next). At a limit, above all of these: compound 2.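

With hexyl on a double-bonded chain carbon bound to a double-bonded chain carbon, the series keeps its level in this assay: a 2.0-fold lower number from compound 3 to compound 4 (0.30 log units; within the scatter), and a 1.4-fold lower number from compound 1 to compound 4 (0.13 log units; within the scatter), both within the scatter, so among these compounds an aromatic ring at this place is not required. Compound 2 is recorded only as a limit of the assay: the limit of > 100000 nM in this assay, at which 1 of the 4 values shown sits. Against that limit, an at least 13-fold lower number from compound 2 to compound 4 (1.13 log units; beyond the scatter), which is beyond the scatter and shows that pyridin-4-yl is the one group among the four that stands apart, while hexyl, 2-methoxyphenyl and 3,4-dimethylphenyl cannot be separated from one another.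

On these data alone, it remains open whether a shorter chain such as butyl or a longer chain such as decyl stays at this level, and how far the chain can be varied before the numbers move beyond the scatter. Also open, as far as these compounds go, is whether an amine at the end of the hexyl chain, or a carboxylic acid there, would match compound 4 or fall away as compound 2 does.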